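The source may report more compounds than this note shows. Statements on the series, on what has been measured and on what is new or still open speak of the compounds shown alone.

Measured so far:
- compound 1 `CCN(CC)C(=O)CN(c1cccc(N(C)C)c1C#N)S(=O)(=O)c1ccc(OC)c(OC)c1`: 110 nM
- compound 2 `CCN(CC)C(=O)CN(c1ccc(C)cc1)S(=O)(=O)c1ccc(OC(F)(F)F)cc1`: 1820 nM
- compound 3 `CCN(C(=O)CN(c1cc(N(C)C)ccc1Cl)S(=O)(=O)c1ccc(OC)c(OC)c1)c1cnc(C)cn1`: 3 nM

In a functional assay on CHO cells for inhibition of Orexin receptor type 2 (Homo sapiens), read by FLIPR and calcium flux (a higher number here means a weaker inhibitor, a lower number a stronger inhibitor), compound 1 gives 110 nM, the second highest of the three numbers. Compound 2 gives a higher number, a gap beyond the scatter, while compound 3 gives a lower number, again beyond the scatter. All three share the same sulfonamide core; they differ in the ring on the sulfonamide nitrogen and in the amide.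

Compound 4 `CCN(CC)C(=O)CN(c1cc(N(C)C)ccc1OC)S(=O)(=O)c1ccc(OC)c(OC)c1` keeps everything of compound 1 except that ring: 5-(dimethylamino)-2-methoxyphenyl in place of 2-cyano-3-(dimethylamino)phenyl on a sulfonamide nitrogen. Compound 3, the strongest inhibitor here, also carries a 5-(dimethylamino) substituted ring with a small group where the nitrile of compound 1 sits, but its amide differs as well, so its low number cannot be credited to the ring alone. With that caution, a modest step toward a lower number in this assay is expected for compound 4, of size a 2.8-fold lower number from compound 1 to compound 4 (0.44 log units; beyond the scatter). Compound 4 is therefore estimated at 40 nM, with a range from 10 nM to 160 nM.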

Compound 4, half-maximal inhibitory concentration: 239 nM
Compound 4: the middle estimate sits 6.0-fold (0.78 log units) below what was measured; measured number above the stated range.
By their numbers in this assay, from the lowest: compound 3; then compound 1; then compound 4; then compound 2.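

In this assay, among these compounds, this is the first change that can be read on its own, since only the ring on the sulfonamide nitrogen differs: 5-(dimethylamino)-2-methoxyphenyl in place of 2-cyano-3-(dimethylamino)phenyl gives a 2.2-fold higher number from compound 1 to compound 4 (0.34 log units; beyond the scatter), a modest step. The two rings match in their counts of heavy atoms and hydrogen-bond acceptors, so those counts alone do not separate them, and with the rest of compound 1 held fixed, the ring that carries the nitrile gives the lower number of this pair. Nothing measured here accounts for the difference between the two rings.

As far as these compounds go, the nitrile, the methoxy group and the place of the dimethylamino group all change together in this one pair, so their separate shares in the step remain open. From the compounds shown here alone, how a ring carrying a hydroxyl group or a primary amine would read on this nitrogen also remains open.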